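The compounds below may be only part of what the source reports. "The series", "measured", "known", "first", "only" and "open" are said of these compounds alone.

Measured compounds in an ADME assay on J774 cells (Mus musculus) for cytotoxicity; on this read-out higher numbers stand for an effect only at larger amounts of compound and lower numbers for an effect already at smaller amounts:
Compound 1 `Cc1[nH]c2c(Cl)cccc2c(=O)c1Cc1ccccc1`: > 35200 nM
Compound 2 `COc1cc2[nH]c(C)c(C3CCCCC3)c(=O)c2cc1Cl`: > 32700 nM

Neither compound has yielded a number in this assay. Compound 2 stands at a limit of the assay, > 32700 nM. Compound 1 also gives only a limit, > 35200 nM. The position of compound 2 is therefore known only as a limit, and its true value cannot be placed relative to that of compound 1.

The next compound, compound 3 `CCCCC/C=C/c1c(C)[nH]c2cc(OC)c(Cl)cc2c1=O`, keeps the core of compound 2 but carries hept-1-en-1-yl in place of cyclohexyl on an aromatic carbon. The ring is swapped for an open chain with one double bond. For the measured compounds named here, no pair of measured compounds differs in only one place, so the size of this change rests on judgement alone. A modest shift toward lower numbers in this assay is expected, and a result that again reaches only a limit would be no surprise. The estimated change is an at least 1.4-fold lower number from compound 2 to compound 3 (0.17 log units; that floor lies within the scatter). For compound 3 the expected value is 22000 nM, with an estimated range of 7000 nM to 40000 nM.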

Compound 3, half-maximal effective concentration: > 31200 nM
Compound 3 ended at the assay's limit; the forecaster's own chance of this, stated with the estimate: 60%; middle value at least 1.4-fold (0.15 log units) away from the limit.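

In this assay compound 3 gives only a limit, > 31200 nM. Compound 2 likewise gives only a limit, and the step from cyclohexyl to hept-1-en-1-yl between compound 2 and compound 3 cannot be read. The compounds shown leave open at what concentration any of them would show an effect in this assay.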